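Hydroxy Addition on Two Cores: Same Change, Different Place

The source may hold more compounds than are shown below. What is called first, only, known or untested is meant among the compounds shown, and "the series" means these compounds.

Compound 1 `COc1ccc(C2CC(Nc3nc4ccc(C)cc4s3)=NN2C(C)=O)cc1` and compound 2 `COc1ccc(C2CC(Nc3nc4ccc(C)cc4s3)=NN2C(C)=O)cc1O` share one core; compound 3 `O=C(/C=C/c1ccccc1)Nc1nc2ccc([N+](=O)[O-])cc2s1` rests on another, and the difference between the two cores is not broken down here. In a functional assay on the whole organism (Hindlimb, strain albino) with Mus musculus as the target, in the maximal electroshock model, with a stated time of 0.5 h (a lower number here means that less compound is needed, a higher number that more compound is needed for the effect), compound 1 gives 37.3 umol/kg, compound 2 gives 73.9 umol/kg and compound 3 gives 485 umol/kg. The change from compound 1 to compound 2, (hydroxy in place of hydrogen on an aromatic carbon), brought a 2.0-fold higher number from compound 1 to compound 2 (0.30 log units; within the scatter). Compound 4 `O=C(/C=C/c1ccc(O)cc1)Nc1nc2ccc([N+](=O)[O-])cc2s1` carries the same kind of change on the core of compound 3, (hydroxy in place of hydrogen on an aromatic carbon); the place is not identical, being para to a large group rather than ortho to a methoxy group and meta to a large group. Going by the values given here, for compound 4 a step of similar size is expected, a 1.5-fold higher number from compound 3 to compound 4 (0.19 log units; within the scatter), because the one prior instance of this change gave a 2.0-fold higher number from compound 1 to compound 2 (0.30 log units; within the scatter). Compound 4 is therefore estimated at 750 umol/kg in this assay, with a range from 320 umol/kg to 1700 umol/kg.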

Compound 4, dose for half-maximal effect: 382 umol/kg
Compound 4: middle estimate off by 2.0-fold (0.29 log units), on the high side, within the range that was stated.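

In this assay, hydroxy in place of hydrogen on the core of compound 3 gave a 1.3-fold lower number from compound 3 to compound 4 (0.10 log units; within the scatter), and the two instances of this change can be compared: the same change on two cores in this assay, a 2.0-fold higher number (0.30 log units; within the scatter) from compound 1 to compound 2 and a 1.3-fold lower number (0.10 log units; within the scatter) from compound 3 to compound 4, 2.5-fold (0.40 log units) apart, within the scatter of two such steps. On these two cores, the change thus shows no difference in effect that can be separated from the scatter, and neither step alone exceeds it. Going by these compounds alone, this does not show that the change transfers reliably across the series: there are only two steps, the hydroxy sits at a different place in each, and neither establishes a real effect.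

The compounds shown leave open whether an amine or a carboxylic acid in place of the hydroxy would give a step beyond the scatter. They also leave open how the hydroxy change would read on a third core.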